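Cytotoxicity in L6 Cells: From a Bromophenyl to a Methoxyphenyl

A few compounds are considered here, and "the series" means these few. Any claim that something is new, unique, unknown or untested is made for them only; others in the source may bear on it.

Measured compounds:
compound 1 `N/C(CC(O)c1ccc2ccccc2c1)=N\N=C\c1ccc(Cl)c(Cl)c1` gives 100000 nM in an ADME assay on L6 cells (Rattus norvegicus) for cytotoxicity, read by resazurin assay, with a stated time of 72 h; on this read-out lower numbers stand for stronger inhibition and higher numbers for weaker inhibition
compound 2 `N/C(CC(O)c1cccc2ccccc12)=N\N=C\c1cccc(Br)c1` gives 3900 nM

In this assay compound 2 holds the lowest of the two numbers shown; its nearest neighbour is compound 1, whose number is higher by a gap that lies beyond the scatter of repeated measurements. Among the compounds with values here, no step between the two measured compounds has been worked out, so only the two values themselves can be compared.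

Compound 3 `COc1ccc(/C=N/N=C(\N)CC(O)c2cccc3ccccc23)cc1` has not yet been measured. It differs from compound 2 in one place: 4-methoxyphenyl in place of 3-bromophenyl on a carbon with a double bond to nitrogen. Within the data shown here, no measured pair shows this kind of change, so its effect cannot be read off from the numbers in hand.

Compound 3 is expected to give a moderately higher number than compound 2 in this assay, a step of a 3.8-fold higher number from compound 2 to compound 3 (0.59 log units; beyond the scatter) that is beyond the scatter but well short of the gap to compound 1. For compound 3 the estimate is 15000 nM, in a range from 4000 nM to 60000 nM.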

Compound 3, half-maximal inhibitory concentration: 6300 nM
The estimate for compound 3 lay 2.4-fold (0.38 log units) above the measured number, and the stated range covers the measured number.
By their numbers in this assay, from the lowest: compounds 2 and 3 (each within the scatter of the next); then compound 1.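

In this assay, within the data shown here, putting 4-methoxyphenyl in place of 3-bromophenyl on a carbon with a double bond to nitrogen gives a 1.6-fold higher number from compound 2 to compound 3 (0.21 log units; within the scatter), the first step that can be read at this position. The change swaps a bromine for an oxygen-bearing group with one hydrogen-bond acceptor, yet the two compounds read alike, so on this shared core the number does not depend on keeping the 3-bromophenyl group. Nothing available speaks to the reason for this result.

This single step alters both the substituent and where it sits on the ring, and only 3-methoxyphenyl and 4-bromophenyl groups could separate those two changes. On these data alone, whether an amine or a carboxylic acid on the ring at this place would move the number beyond the scatter also remains open.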